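Tail amine swap from compound 1 to compound 4

The source may hold more compounds than are shown below. What is called first, only, known or untested is meant among the compounds shown, and "the series" means these compounds.

Measured so far:
compound 1 `CCN(CC)CCn1cnnc1-c1cc(Oc2ccc(NC(=O)Nc3ccccc3C(F)(F)F)cc2F)ccn1` gives 23500 nM
compound 2 `CCN(CC)CCn1cnnc1-c1cc(Oc2ccc(NC(=O)Nc3ccc(F)c(F)c3)cc2F)ccn1` gives > 50000 nM
compound 3 `CCN(CC)CCn1cnnc1-c1cc(Oc2ccc(NC(=O)Nc3ccc(Cl)cc3Cl)cc2F)ccn1` gives 4280 nM

In an ADME assay on WI-38 cells (Homo sapiens) for cytotoxicity, read by MTT assay, with a stated time of 72 h (a higher number here means a weaker inhibitor, a lower number a stronger inhibitor), compound 1 stands at 23500 nM, the highest of the two numbers shown. Compound 3 sits clearly below it: a 5.5-fold lower number from compound 1 to compound 3 (0.74 log units; beyond the scatter). For compound 2 the assay reports only a limit, > 50000 nM, and not a number (the limit of > 50000 nM in this assay, at which 1 of the 3 values shown sits). The remaining steps are an at least 2.1-fold higher number from compound 1 to compound 2 (0.32 log units; beyond the scatter) and an at least 11-fold lower number from compound 2 to compound 3 (1.06 log units; beyond the scatter). All three measured steps vary the aryl group on the amide-type nitrogen and leave the amine tail untouched.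

Compound 4 `CN(C)CCCn1cnnc1-c1cc(Oc2ccc(NC(=O)Nc3ccccc3C(F)(F)F)cc2F)ccn1` differs from compound 1 in that tail only: (dimethylamino)methyl in place of diethylamino on a saturated chain carbon, two bonds along the chain from an aromatic nitrogen. Among the measured compounds shown here, none of the measured steps bears on this kind of change, so there is no measured precedent for its size or direction. In the absence of such evidence, no step beyond the scatter is expected from compound 1 to compound 4, which amounts to an expected no change at the digits printed from compound 1 to compound 4 (within the scatter). Compound 4 is therefore estimated at 23500 nM, with a range from 10000 nM to 50000 nM, the upper end acknowledging that the assay may again return only a limit.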

Compound 4, half-maximal inhibitory concentration: 28600 nM
Compound 4: the middle estimate sits 1.2-fold (0.09 log units) below what was measured, and the stated range covers the measured number.
By their numbers in this assay, from the lowest: compound 3; then compounds 1 and 4 (each within the scatter of the next). At a limit, above all of these: compound 2.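

In this assay, the tail position now has a measured step of its own: a 1.2-fold higher number from compound 1 to compound 4 (0.09 log units; within the scatter). With 2-(trifluoromethyl)phenyl held on the amide-type nitrogen, 3-(dimethylamino)propyl in place of 2-(diethylamino)ethyl therefore does not separate compound 4 from compound 1, whereas an aryl swap at the amide-type nitrogen does move the number beyond the scatter: a 5.5-fold lower number from compound 1 to compound 3 (0.74 log units; beyond the scatter). Nothing at hand accounts for the tail swap's result.

This swap alters the chain and the amine substituents together, so a 2-(dimethylamino)ethyl or a 3-(diethylamino)propyl tail would be needed to show whether each alteration alone also stays within the scatter, or whether the two merely offset each other. Also open, going by these compounds, is whether the same tail swap stays within the scatter with the 2,4-dichlorophenyl group of compound 3 on the amide-type nitrogen, and what a primary amine, a carboxylic acid or a longer chain would do at this position.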